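Swapping a Chlorophenyl for a Furan in Compound 4

A few compounds are considered here, and "the series" means these few. Any claim that something is new, unique, unknown or untested is made for them only; others in the source may bear on it.

Of the compounds shown here, three built on one shared core have been tested in a functional assay on HepG2 cells (Homo sapiens) for cytotoxicity, read by sulforhodamine B assay, with a stated time of 72 h; on this read-out higher numbers stand for weaker inhibition and lower numbers for stronger inhibition. Compound 1 `Cc1c(-c2csc(NC(=S)Nc3ccccc3)n2)c(=O)n(-c2ccccc2)n1C` gives 8350 nM in this assay. Compound 2 `CCOC(=O)c1nn(-c2ccccc2)/c(=N/c2nc(-c3c(C)n(C)n(-c4ccccc4)c3=O)cs2)s1` returns only the limit of this assay, reported as > 100000 nM. Compound 3 `Cc1c(-c2csc(/N=C3\S/C(=C\c4ccc(Cl)cc4)C(=O)N3c3ccccc3)n2)c(=O)n(-c2ccccc2)n1C`, which carries a 4-chlorophenyl group on a double-bonded chain carbon bound to a double-bonded ring carbon, likewise returns only a limit, > 100000 nM, so no actual number is known for it. Across the set, (the limit of > 100000 nM in this assay, at which 2 of the 3 values shown sit), which leaves little room to read trends. Compound 4 `Cc1c(-c2csc(/N=C3\S/C(=C\c4ccco4)C(=O)N3c3ccccc3)n2)c(=O)n(-c2ccccc2)n1C` differs from compound 3 in exactly one place: furan-2-yl in place of 4-chlorophenyl on a double-bonded chain carbon bound to a double-bonded ring carbon. For the measured compounds named here, no two measured compounds differ in a single place, so the usual size of such a swap cannot be read from these data. Starting from a limit, the step of an at least 1.1-fold lower number from compound 3 to compound 4 (0.04 log units; that floor lies within the scatter) is expected to be none beyond the scatter, meaning compound 4 would most likely also sit at or near the limit. Compound 4 is estimated at 90000 nM, with a range from 20000 nM to 300000 nM.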

Compound 4, half-maximal inhibitory concentration: 16700 nM
The estimate for compound 4 lay 5.4-fold (0.73 log units) above the measured number, outside the stated range (below it).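

For the compounds shown here, this is the first single-place change in this assay that gives a readable result: an at least 5.9-fold lower number from compound 3 to compound 4 (0.77 log units; beyond the scatter). It shows that the group on a double-bonded chain carbon bound to a double-bonded ring carbon matters to this read-out, since furan-2-yl in place of 4-chlorophenyl brings the compound from a limit to a real number. The true size of this step remains unknown, and only its lower bound can be stated, because compound 3 gives a limit rather than a number: the limit of > 100000 nM in this assay, at which 2 of the 4 values shown sit.

Going by these compounds, it remains open whether a plain phenyl at this place would behave more like 4-chlorophenyl or more like furan-2-yl. It is also unclear how other groups here, such as thiophene, an amine or a carboxylic acid, would shift the number.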